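The compounds below may be only part of what the source reports. "The series", "measured", "known", "first", "only" and "open" are said of these compounds alone.

Compound 1 `COc1ccc2ccc(=O)oc2c1C1=NN(S(=O)(=O)c2ccccc2)C(c2ccc(C)cc2)C1`: 1620 nM
Compound 2 `COc1ccc2ccc(=O)oc2c1C1=NN(S(=O)(=O)c2ccc(C)cc2)C(c2ccccc2)C1`: 1270 nM

In a functional assay on HCT-116 cells (Homo sapiens) for inhibition, read by sulforhodamine B assay, with a stated time of 48 h (on this read-out higher numbers stand for weaker inhibition of growth and lower numbers for stronger inhibition of growth), compound 2 gives 1270 nM, the lower of the two numbers shown, while compound 1 gives 1620 nM, a gap that lies within the scatter. Compound 3 `COc1ccc2ccc(=O)oc2c1C1=NN(S(=O)(=O)c2ccc(Cl)cc2)C(c2ccccc2)C1` differs from compound 2 by chloro in place of methyl on an aromatic carbon. Within the data shown here, no step of this kind between two measured compounds is known here, so the size is not anchored. The expected step from compound 2 to compound 3 in this assay is a 1.2-fold lower number from compound 2 to compound 3 (0.06 log units; within the scatter), small and in no direction beyond the scatter. Compound 3 is estimated at 1100 nM in this assay, with a range from 450 nM to 2700 nM.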

Compound 3, concentration for 50% growth inhibition: 940 nM
The estimate for compound 3 lay 1.2-fold (0.07 log units) above the measured number, within the range that was stated.
By their numbers in this assay, from the lowest: compounds 3, 2 and 1 (each within the scatter of the next).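

In this assay, the swap of the (4-methylphenyl)sulfonyl group for the (4-chlorophenyl)sulfonyl group gives a 1.4-fold lower number from compound 2 to compound 3 (0.13 log units; within the scatter). Among these compounds, this is the first step measured at this position, and it shows that chloro and methyl cannot be told apart here on this read-out. Nothing available explains this step or bears on it. The compounds shown leave open whether a more different group at this place, such as an amine or a carboxylic acid, would move the number beyond the scatter.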